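The compounds below may be only part of what the source reports. "The series", "measured", "known", "first", "only" and "open" are said of these compounds alone.

Working notes on the series.

Compound 1 `N#CCC1=C(C#N)CC(c2ccc([N+](=O)[O-])cc2)=C(CC(=O)c2ccc([N+](=O)[O-])cc2)O1` carries two nitro groups, and in a functional assay on SF-268 cells (Homo sapiens) for inhibition, read by sulforhodamine B assay, with a stated time of 48 h (a lower number here means a stronger inhibitor of growth, a higher number a weaker inhibitor of growth), compound 1 gives 5 nM. Compound 3 `N#CCC1=NN=C(c2ccc([N+](=O)[O-])cc2)C(Br)O1` is built on a different core; the difference between the two cores is not broken down here. In this assay compound 3 gives 6700 nM, and compound 2 `N#CCC1=NN=C(c2ccc(Br)cc2)C(Br)O1` gives 32000 nM. Between these two the change is bromo in place of nitro on an aromatic carbon; it made a 4.8-fold higher number from compound 3 to compound 2 (0.68 log units; beyond the scatter).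

Compound 4 `N#CCC1=C(C#N)CC(c2ccc(Br)cc2)=C(CC(=O)c2ccc([N+](=O)[O-])cc2)O1` is not yet measured. The change from compound 1 to compound 4 is bromo in place of nitro on an aromatic carbon, the same change as from compound 3 to compound 2, at the same kind of place, with the other nitro group of compound 1 kept. Among the compounds here this change appears twice. The expectation for compound 4 rests on the step already seen, because a 4.8-fold higher number from compound 3 to compound 2 (0.68 log units; beyond the scatter) points to a weaker inhibitor when bromo replaces nitro, though on a different core. The expected step is a 4.0-fold higher number from compound 1 to compound 4 (0.60 log units; beyond the scatter). Compound 4 is expected to give 20 nM, with a likely range from 5 nM to 90 nM.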

Compound 4, concentration for 50% growth inhibition: 3 nM
Compound 4: the middle estimate sits 6.7-fold (0.82 log units) above what was measured, outside the stated range (below it).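

In this assay, bromo in place of nitro on an aromatic carbon gives a 1.7-fold lower number from compound 1 to compound 4 (0.22 log units; within the scatter), a step that leaves the two compounds level within the scatter. The change therefore does not carry over in size from one core to the other, and the step seen on the core of compound 3 is no guide to the core of compound 1: the same change on two cores in this assay, a 4.8-fold higher number (0.68 log units; beyond the scatter) from compound 3 to compound 2 and a 1.7-fold lower number (0.22 log units; within the scatter) from compound 1 to compound 4, 8.0-fold (0.90 log units) apart, beyond the scatter of two such steps. This rests on a single pair on each core, and it does not show which feature of the two cores goes with the difference, nor whether any other change would differ between them in the same way.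

On these data alone, how compound 1 and compound 4 would read with their remaining nitro group replaced on the shared core stays open. Also open, as far as these compounds go, is how an amine or a carboxylic acid would read at the place held by nitro or bromo on either core.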